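The compounds below may be only part of what the source reports. "The series", "measured", "known", "first", "only" and "open" are said of these compounds alone.

Measured in a functional assay on HeLa cells for antagonist activity at 5-hydroxytryptamine receptor 6 (Homo sapiens), read by cAMP accumulation, with stated times of 10 min and 30 min; a lower number here means a stronger inhibitor, a higher number a weaker inhibitor:
- compound 1 `COc1cccc(S(=O)(=O)Nc2n[nH]c3c2CCN(c2ccc(C)cc2)C3=O)c1`: 6770 nM
- compound 2 `COc1ccc(N2CCc3c(NS(=O)(=O)c4cccc(F)c4)n[nH]c3C2=O)cc1`: 580 nM
- compound 3 `O=C1c2[nH]nc(NS(=O)(=O)c3cccc4ccccc34)c2CCN1C1CCNCC1`: 770 nM

Compound 3 stands second highest of the three numbers in this assay. Its nearest neighbour is compound 2, whose value lies within the scatter of it, so no order between the two can be read. Compound 1 is the furthest away, with a clearly higher number, beyond the scatter.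

Compound 4 `O=C1c2[nH]nc(NS(=O)(=O)c3cccc4ccccc34)c2CCN1CC1CCNCC1` is not yet measured. It differs from compound 3 in one place: (piperidin-4-yl)methyl in place of piperidin-4-yl on an amide-type nitrogen in a ring. Among the compounds with values here, no step between measured compounds of this kind is available, so the size of the step in this assay is unknown; a small change of this sort is expected to stay within the scatter, or at most to raise the number a little. For compound 4 the expected value is 950 nM (range 300 nM to 3000 nM), an expected step of a 1.2-fold higher number from compound 3 to compound 4 (0.09 log units; within the scatter).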

Compound 4, half-maximal inhibitory concentration: 310 nM
Beside the measured number, compound 4's estimate is 3.1-fold (0.49 log units) above it; the measured number falls inside the stated range.
By their numbers in this assay, from the lowest: compounds 4, 2 and 3 (each within the scatter of the next, the first and the last beyond it); then compound 1.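

In this assay the (piperidin-4-yl)methyl group in place of piperidin-4-yl on the amide-type nitrogen in a ring gives a 2.5-fold lower number from compound 3 to compound 4 (0.40 log units; beyond the scatter), a modest step beyond the scatter. Within the data shown here, this is the first reading of this position: it responds to a small extension, with the piperidine ring and the donor and acceptor counts unchanged. No measurement at hand bears on the reason for this step.

Still open, on these data alone, is whether a longer chain, such as (piperidin-4-yl)ethyl, lowers the number further. Also open, as far as these compounds go, is whether an open-chain amine, such as 2-aminoethyl, serves on this nitrogen.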